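Replacing 2H-indazol-2-yl with 4-chloro-1H-pyrazol-1-yl

The compounds below may be only part of what the source reports. "The series", "measured", "known", "first", "only" and "open" are said of these compounds alone.

Among the measured compounds shown here, in an ADME assay on microsomes from liver (Homo sapiens) for metabolic stability (a lower number here means slower removal, a higher number faster removal of the compound), compound 1 `CCCC(Oc1ccc(-n2cc3ccccc3n2)cc1)c1ccc(C(=O)NCCC(=O)O)cc1` gives 44 mL/min/kg, the only exact number available. Compound 2 `CCC(Oc1ccc(-n2cc(C(F)(F)F)cn2)cc1)c1ccc(C(=O)NCCC(=O)O)cc1` reads < 8 mL/min/kg, which is a limit of the assay and not a number, and this is the sole hint towards slower removal for compound 3. Compound 3 `CCCC(Oc1ccc(-n2cc(Cl)cn2)cc1)c1ccc(C(=O)NCCC(=O)O)cc1` carries 4-chloro-1H-pyrazol-1-yl in place of 2H-indazol-2-yl on an aromatic carbon. For the measured compounds named here, no measured step isolates this change, but a fall beyond the usual scatter is expected in this assay, estimated as a 2.4-fold lower number from compound 1 to compound 3 (0.39 log units; beyond the scatter). Compound 3 is estimated at 18 mL/min/kg, with an expected range of 8 mL/min/kg to 40 mL/min/kg.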

Compound 3, clearance: 10 mL/min/kg
The estimate for compound 3 lay 1.8-fold (0.26 log units) above the measured number; low and high end bracket the measured number.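

In this assay, among the compounds shown here, the first measured step at this position, on an aromatic carbon para to a large group, 4-chloro-1H-pyrazol-1-yl in place of 2H-indazol-2-yl gives a 4.4-fold lower number from compound 1 to compound 3 (0.64 log units; beyond the scatter). A single five-membered aromatic ring carrying chlorine can therefore replace the two-ring group with a clear fall in clearance. Compound 2 reads a limit of the assay, not a number: the limit of < 8 mL/min/kg in this assay, at which 1 of the 3 values shown sits.

As far as these compounds go, it remains open whether the loss of the six-membered aromatic ring or the arrival of the chlorine carries this fall. From the compounds shown here alone, how a nitrile or a methyl group in place of the chlorine would read also remains open.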